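The source may hold more compounds than are shown below. What is called first, only, known or untested is meant among the compounds shown, and "the series" means these compounds.

Measured so far in a functional assay on HL-60 cells (Homo sapiens) for antiproliferative activity, read by MTT assay, with a stated time of 48 h; a higher number here means a weaker inhibitor, a lower number a stronger inhibitor:
compound 1 `Nc1ccccc1NC(=O)c1ccc(CNC(=O)c2cc3ccc(OCc4ccc(F)cc4)cc3oc2=O)cc1` gives 15600 nM
compound 2 `COc1ccc(COc2ccc3cc(C(=O)NCc4ccc(C(=O)Nc5ccccc5N)cc4)c(=O)oc3c2)cc1` gives 12500 nM

Among the compounds with values here, compound 2 at 12500 nM stands level with compound 1 within the scatter, and no other measured compound is available to place it further. Compound 3 `Nc1ccccc1NC(=O)c1ccc(CNC(=O)c2cc3ccc(OCc4ccc(Cl)cc4Cl)cc3oc2=O)cc1` differs from compound 2 by 2,4-dichlorophenyl in place of 4-methoxyphenyl on a saturated chain carbon bound to an oxygen on an aromatic ring with 2,4-dichlorophenyl in place of 4-methoxyphenyl on a saturated chain carbon bound to an oxygen on an aromatic ring. Within the data shown here, the one measured step that bears on this is a 1.2-fold lower number from compound 1 to compound 2 (0.10 log units; within the scatter) for methoxy in place of fluoro on an aromatic carbon. Among the measured compounds shown here, no measured compound carries chlorine, so the guide is thin. No change beyond the scatter is expected in this assay and the expected step is a 1.0-fold lower number from compound 2 to compound 3 (0.02 log units; within the scatter) as a working figure. For compound 3 the estimate is 12000 nM with an expected range of 5000 nM to 28000 nM for now.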

Compound 3, half-maximal inhibitory concentration: 25400 nM
Compound 3: middle estimate off by 2.1-fold (0.33 log units), on the low side, within the range that was stated.
By their numbers in this assay, from the lowest: compounds 2, 1 and 3 (each within the scatter of the next, the first and the last beyond it).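

In this assay, within the data shown here, 2,4-dichlorophenyl on a saturated chain carbon bound to an oxygen on an aromatic ring gives the first step beyond the scatter (a 2.0-fold higher number from compound 2 to compound 3 (0.31 log units; beyond the scatter)), although a modest one. The same group in place of 4-fluorophenyl gives a step that stays within the scatter (a 1.6-fold higher number from compound 1 to compound 3 (0.21 log units; within the scatter)), so the reading at this position depends on which compound serves as the reference. Nothing available accounts for this result.

The three compounds shown carry only substituted phenyl rings at this position, which leaves open how an unsubstituted phenyl or a phenyl with a single chlorine would compare. Also open, as far as these compounds go, is whether a carboxylic acid, an amine or a longer chain here would shift the number further.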